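The source may hold more compounds than are shown below. What is called first, only, known or untested is meant among the compounds shown, and "the series" means these compounds.

Three measured compounds share one core. In a functional assay on MDA-MB-231 cells (Homo sapiens) for inhibition (a higher number here means a weaker inhibitor of growth, a lower number a stronger inhibitor of growth), compound 1 `COc1cc(/C=C/C(=O)c2cccc(-n3cc(-c4ccc(Cl)cc4)[nH]c3=O)c2)cc(OC)c1OC` gives 13800 nM. Compound 2 `COc1cc(/C=C/C(=O)c2cccc(-n3cc(-c4ccccc4)[nH]c3=O)c2)cc(OC)c1OC` gives 2170 nM, and compound 3 `COc1ccc(-c2cn(-c3cccc(C(=O)/C=C/c4cc(OC)c(OC)c(OC)c4)c3)c(=O)[nH]2)cc1` gives 5480 nM. Compound 3 thus stands second highest of the three: a 2.5-fold higher number from compound 2 to compound 3 (0.40 log units; beyond the scatter), while a 2.5-fold lower number from compound 1 to compound 3 (0.40 log units; beyond the scatter). Compound 4 `COc1cc(/C=C/C(=O)c2cccc(-n3cc(-c4cc(OC)c(OC)c(OC)c4)[nH]c3=O)c2)cc(OC)c1OC` differs from compound 3 by 3,4,5-trimethoxyphenyl in place of 4-methoxyphenyl on an aromatic carbon. Within the data shown here, no measured step places a trimethoxyphenyl here; the step that bears on it most is a 2.5-fold higher number from compound 2 to compound 3 (0.40 log units; beyond the scatter), where a single methoxy entered, and a 6.4-fold lower number from compound 1 to compound 2 (0.80 log units; beyond the scatter) shows how much this position can move. Two further methoxy groups are therefore expected to raise the number only modestly, and the expected step is a 1.6-fold higher number from compound 3 to compound 4 (0.22 log units; within the scatter). Compound 4 is estimated at 9000 nM, between 3000 nM and 27000 nM.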

Compound 4, concentration for 50% growth inhibition: 4190 nM
Compound 4: middle estimate off by 2.1-fold (0.33 log units), on the high side; the measured number falls inside the stated range.
By their numbers in this assay, from the lowest: compounds 2, 4 and 3 (each within the scatter of the next, the first and the last beyond it); then compound 1.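

In this assay the step to three methoxy groups gives a 1.3-fold lower number from compound 3 to compound 4 (0.12 log units; within the scatter) and the step from the unsubstituted phenyl gives a 1.9-fold higher number from compound 2 to compound 4 (0.29 log units; within the scatter), so adding methoxy groups here produces no steady rise in the number, even though compound 2 and compound 3 differ beyond the scatter. The 4-chlorophenyl group remains the outlier, with a 3.3-fold lower number from compound 1 to compound 4 (0.52 log units; beyond the scatter), and compound 1 is beyond the scatter of all three others. Nothing available explains these differences. The compounds shown leave open how an amine or a carboxylic acid on this phenyl ring would read in this assay, and whether fluoro or bromo would follow chloro.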